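The compounds below may be only part of what the source reports. "The series", "measured", "known", "first", "only" and "open" are said of these compounds alone.

Compound 3 `CCC(=O)Nc1ccc(Nc2cccc(OC)c2)cc1` gives 61 nM in an assay on isolated protein for binding affinity to melatonin receptor type 1A (Homo sapiens) (a higher number here means a weaker inhibitor, a lower number a stronger inhibitor), the lowest of the two numbers reported. Compound 1 `CCC(=O)Nc1ccc(Oc2cccc(OC)c2)cc1` gives 300 nM in this assay, a higher number. Compound 2 `CCNC(=O)Nc1ccc(Oc2cccc(OC)c2)cc1` reaches only a limit, > 500 nM, in this assay, which is an assay boundary rather than a number (the limit of > 500 nM in this assay, at which 1 of the 3 values shown sits). Going by the values given here, the single measured step, an at least 1.6-fold higher number from compound 1 to compound 2 (0.22 log units; that floor lies within the scatter), replaces the alkyl chain on the carbonyl with an amino group.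

Compound 4 `CCCC(=O)Nc1ccc(Nc2cccc(OC)c2)cc1` differs from compound 3 by methyl in place of hydrogen on a saturated chain carbon, two bonds along the chain from a carbonyl carbon. Among the compounds with values here, no measured step involves a lengthening of the chain by one carbon, so no direct guidance exists; the change is small in size. The step from compound 3 to compound 4 is therefore expected to stay within the scatter, a 1.2-fold lower number from compound 3 to compound 4 (0.09 log units; within the scatter). Compound 4 is estimated at 50 nM, between 20 nM and 150 nM.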

Compound 4, inhibition constant: 31 nM
Compound 4: middle estimate off by 1.6-fold (0.21 log units), on the high side, within the range that was stated.
By their numbers in this assay, from the lowest: compounds 4 and 3 (each within the scatter of the next); then compound 1. At a limit, above all of these: compound 2.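

In this assay, going from propanoyl to propylcarbonyl gives a 2.0-fold lower number from compound 3 to compound 4 (0.29 log units; within the scatter) and so leaves the two compounds indistinguishable. Going by these compounds alone, the added methyl on this saturated chain carbon therefore neither clearly helps nor clearly harms, something the earlier compounds, which never varied the chain length, could not show. Nothing shown here explains this step.

Going by these compounds, whether a longer chain or a cyclopropyl ring on the carbonyl would keep numbers like these remains open. So does whether a branched chain would be accepted at this same carbon.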